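Swapping Cyclohexyl for Phenyl on an Amide Carbonyl

The source may report more compounds than this note shows. Statements on the series, on what has been measured and on what is new or still open speak of the compounds shown alone.

Of the compounds shown here, two built on a shared core have been tested in a toxicity assay on THP-1 cells (Homo sapiens) for inhibition; on this read-out lower numbers stand for higher toxicity in this test and higher numbers for lower toxicity in this test. Compound 1 `COc1ccc(-c2cnc(NC(=O)C3CCCCC3)n2C)cc1` carries a cyclohexyl on its amide carbonyl. In this assay compound 1 gives > 100000 nM, which is a limit of the assay rather than a number. Compound 2 `COc1ccc(-c2ccnc(NC(=O)c3ccc(F)cc3)c2)cc1` also reaches only a limit in this assay, > 100000 nM. Compound 1 thus stands at the limit of > 100000 nM in this assay, at which 2 of the 2 values shown sit, so both measured compounds sit at the same limit and nothing distinguishes them.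

The next compound, compound 3 `COc1ccc(-c2cnc(NC(=O)c3ccccc3)n2C)cc1`, differs from compound 1 in one place: phenyl in place of cyclohexyl on a carbonyl carbon. The cyclohexyl leaves and a phenyl enters on the carbonyl carbon. With both known values at a limit, the step of a number no higher from compound 1 to compound 3 (the limit leaves the size open) is expected to be none beyond the scatter in this assay. Compound 3 is therefore estimated to give about 100000 nM in this assay, between 30000 nM and 300000 nM, most likely again reported only as a limit.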

Compound 3, half-maximal cytotoxic concentration: > 100000 nM
Compound 3 was reported as a limit; the forecaster's own chance of this, stated with the estimate: 80%; the middle value sits exactly at the limit.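

In this assay compound 3 gives > 100000 nM, which is again a limit and not a number. No step can therefore be read between compound 1 and compound 3, and all three compounds stay indistinguishable: the limit of > 100000 nM in this assay, at which 3 of the 3 values shown sit.

The compounds shown leave open whether phenyl in place of cyclohexyl on a carbonyl carbon changes the toxicity read-out at all, and at what concentration any of these compounds would become toxic to the cells.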